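The compounds below may be only part of what the source reports. "The series", "measured", "known", "first", "only" and "open" are said of these compounds alone.

Values from a physicochemical assay for lipophilicity, at pH 7.4 (on this read-out lower numbers stand for lower lipophilicity and higher numbers for higher lipophilicity), for the compounds measured so far:

- compound 1 (`CCCCOc1ncc(S(=O)(=O)N2CCN(CC)CC2)cc1-c1nc2c(CC)n(C3CN(C)C3)nc2c(=O)[nH]1`) gives 2.8
- compound 2 (`CCCn1nc2c(=O)[nH]c(-c3cc(S(=O)(=O)N4CCN(C)CC4)cnc3OCCOC)nc2c1CC`) gives 1
- compound 3 (`CCc1c2nc(-c3cc(S(=O)(=O)N4CCN(CC)CC4)cnc3OCCOC)[nH]c(=O)c2nn1C(C)C`) gives 1

Compound 3 stands level with compound 2 at the low end of this small set, and the two share the same number at the digits shown. Compound 1 lies higher than both, by a gap well beyond the scatter of repeated measurements.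

The next compound to be measured is compound 4 (`CCc1c2nc(-c3cc(S(=O)(=O)N4CCN(CC)CC4)cnc3OCCOC)[nH]c(=O)c2nn1CC1CC1`). It has cyclopropylmethyl in place of isopropyl on an aromatic nitrogen, and the rest of compound 3 stays as it is. Both groups are made of carbon only, and neither carries a charge.

Among the measured compounds shown here, no two measured compounds differ in one place only, so no measured step shows how this assay responds to this swap. The expectation therefore rests on the structural change and on compound 3 at 1 as the starting point. The estimated step of a number 0.10 log units higher from compound 3 to compound 4 (within the scatter) is a small upward one that stays within the scatter. Compound 4 is expected at 1.1 in a range from 0.7 to 1.6 once measured.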

Compound 4, distribution coefficient: 1
Compound 4: middle estimate off by 0.10 log units, on the high side, within the range that was stated.
By their numbers in this assay, from the lowest: compounds 2, 3 and 4 (each within the scatter of the next); then compound 1.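

Among the compounds shown here, at this place, on an aromatic nitrogen of a five-membered aromatic ring and next to the ring atom that bears an ethyl group, putting cyclopropylmethyl in place of isopropyl gives no change at the digits printed from compound 3 to compound 4 (within the scatter) in this assay, and this is the first measured comparison in which only one place differs. The entering group brings one more carbon and a three-membered ring, yet at this nitrogen the read-out does not tell the two compounds apart, so here these two carbon-only groups can be treated as interchangeable for this measurement. Nothing available explains this result, so the reason for it remains unknown.

The compounds shown leave open how this assay would respond at this nitrogen to a group of a different kind, such as an amine or a carboxylic acid, or to a longer carbon chain. For the compounds shown here, they also leave open whether cyclopropylmethyl and isopropyl would still match if the rest of the molecule were different, since this single pair is the only direct comparison so far.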